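A few compounds are considered here, and "the series" means these few. Any claim that something is new, unique, unknown or untested is made for them only; others in the source may bear on it.

Three measured compounds share one core and differ only in the group on one aromatic carbon. Compound 1 `Brc1cn2ccnc2c(-c2ccc3ncn(C4CCCCC4)c3c2)n1` carries a bromo there and in a functional assay on NCI-H23 cells (Homo sapiens) for inhibition, read by sulforhodamine B assay, with a stated time of 48 h, tested at 10 uM (a lower number here means less inhibition, a higher number more inhibition at the concentration tested (going by the name of the read-out)), compound 1 gives 10.2%. Compound 2 `c1ccc(-c2cn3ccnc3c(-c3ccc4ncn(C5CCCCC5)c4c3)n2)cc1` carries a phenyl, and compound 2 gives 45.3%. Compound 3 `O=Cc1ccc(-c2cn3ccnc3c(-c3ccc4ncn(C5CCCCC5)c4c3)n2)cc1` carries a 4-formylphenyl, and compound 3 gives 54.5%, the highest number of the three; the gap to compound 2 lies within the scatter, while the gap to compound 1 is large, a number 44.3 percentage points higher from compound 1 to compound 3 (beyond the scatter).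

Compound 4 `Clc1ccc(-c2cn3ccnc3c(-c3ccc4ncn(C5CCCCC5)c4c3)n2)cc1` differs from compound 3 in one place: chloro in place of formyl on an aromatic carbon. Among the compounds with values here, no measured step introduces a chloro, so the nearest guide is a number 9.2 percentage points higher from compound 2 to compound 3 (within the scatter), which shows that adding or removing the formyl on that ring changes little. A chloro in the same place is therefore expected to leave the number close to that of compound 3 and compound 2, with no step beyond the scatter.

Compound 4 is estimated at 48%, between 30% and 65%, an expected step of a number 6.5 percentage points lower from compound 3 to compound 4 (within the scatter).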

Compound 4, a percentage reported as inhibition, at one concentration (the size of the read-out at that concentration, not a potency): 4.11%
Estimate against measurement, compound 4: 43.9 percentage points above; the measured number lies below the stated range.
By their numbers in this assay, from the lowest: compounds 4 and 1 (each within the scatter of the next); then compounds 2 and 3 (each within the scatter of the next).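

In this assay, the group on this ring carbon turns out to matter a great deal: chloro in place of formyl gives a number 50.4 percentage points lower from compound 3 to compound 4 (beyond the scatter), and chloro in place of hydrogen gives a number 41.2 percentage points lower from compound 2 to compound 4 (beyond the scatter), so the earlier formyl step, which stayed within the scatter, did not mean that any group would be accepted here. Having a phenyl ring at this point of the core is therefore not enough on its own, since 4-chlorophenyl in place of bromo gives only a number 6.1 percentage points lower from compound 1 to compound 4 (within the scatter). Nothing available explains why this one change has so large an effect.

From the compounds shown here alone, it remains open whether the drop is particular to chloro or shared by other groups at this carbon. A fluoro, a methoxy or an amine in the same place could side with compound 4 or with compound 3.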